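Swapping the indole for a cyanophenyl on the piperidine arm

The source may hold more compounds than are shown below. What is called first, only, known or untested is meant among the compounds shown, and "the series" means these compounds.

Measured so far:
- compound 1 `O=C1OC(c2ccncc2)CN1C1CCN(Cc2cc3ccccc3[nH]2)CC1`: < 50200 nM
- compound 2 `COc1ccc2nccc(C3CN(C4CCN(Cc5c[nH]c6ccccc56)CC4)C(=O)O3)c2c1`: < 50200 nM

Both compounds were tested in an in vitro functional assay on RBL cells for antagonist activity at C-C chemokine receptor type 8 (Homo sapiens), read by FLIPR and calcium flux; a higher number here means a weaker inhibitor, a lower number a stronger inhibitor. For compound 1 the result < 50200 nM is a limit of the assay rather than a number. For compound 2 the result < 50200 nM is likewise only a limit. Compound 2 therefore stands nowhere definite on the scale; all that is known is that it reaches the limit described in the limit of < 50200 nM in this assay, at which 2 of the 2 values shown sit, as does compound 1. For the measured compounds named here, no step between two measured compounds is available, so nothing here tells how much a change to the group on the piperidine arm shifts the read-out.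

Compound 3 `COc1ccc2nccc(C3CN(C4CCN(Cc5ccc(C#N)cc5)CC4)C(=O)O3)c2c1` is the next compound to be measured. It differs from compound 2 in one place: 4-cyanophenyl in place of 1H-indol-3-yl on a saturated chain carbon bound to an amine nitrogen in a ring. With both known values sitting at a limit, there is no basis for expecting a step in either direction beyond the scatter; the step from compound 2 to compound 3 is expected to be a step that the limit leaves unreadable from compound 2 to compound 3. The expected value for compound 3 in this assay is 5000 nM, within a range from 500 nM to 50000 nM.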

Compound 3, half-maximal inhibitory concentration: 12600 nM
Compound 3: middle estimate off by 2.5-fold (0.40 log units), on the low side; the measured number falls inside the stated range.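

For the compounds shown here, no step from compound 2 to compound 3 can be read, because the result for compound 2 in this assay is a limit of the assay and not a number: the limit of < 50200 nM in this assay, at which 2 of the 3 values shown sit.

The compounds shown leave open whether 4-cyanophenyl in place of 1H-indol-3-yl makes inhibition stronger, makes it weaker, or leaves it unchanged.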